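The source may hold more compounds than are shown below. What is called first, only, known or untested is meant among the compounds shown, and "the series" means these compounds.

Among the compounds with values here, compound 2 `CN(C)c1nc(Nc2ccc(C(F)(F)F)cc2)c2nc(Nc3c(Cl)cccc3Cl)sc2n1` gives 43 nM in a functional assay on HEK293 cells for antagonist activity at transient receptor potential cation channel subfamily V member 1 (Rattus norvegicus), read by calcium flux (on this read-out higher numbers stand for weaker inhibition and lower numbers for stronger inhibition), the higher of the two numbers so far; its closest neighbour is compound 1 `FC(F)(F)c1ccc(Nc2nc(N3CCCC3)nc3sc(Nc4c(Cl)cccc4Cl)nc23)cc1`, which in this assay gives 36 nM. Within the data shown here, the one step between them, a 1.2-fold higher number from compound 1 to compound 2 (0.08 log units; within the scatter), involves a change at the same aromatic carbon as the one now considered. Compound 3 `CC(C)Nc1nc(Nc2ccc(C(F)(F)F)cc2)c2nc(Nc3c(Cl)cccc3Cl)sc2n1` differs from compound 2 by isopropylamino in place of dimethylamino on an aromatic carbon. Among the measured compounds shown here, no measured pair covers a tertiary-to-secondary amine exchange at that carbon, so the only guide is the size of the earlier step, which stayed within the scatter. A move of about the same size is therefore expected, with no reliable direction; the estimated step is a 1.4-fold higher number from compound 2 to compound 3 (0.14 log units; within the scatter). In this assay compound 3 is expected to give about 60 nM, with a likely range from 20 nM to 200 nM.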

Compound 3, half-maximal inhibitory concentration: 9 nM
The estimate for compound 3 lay 6.7-fold (0.82 log units) above the measured number; the whole stated range lies above it.
By their numbers in this assay, from the lowest: compound 3; then compounds 1 and 2 (each within the scatter of the next).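

At the aromatic carbon between two ring nitrogen atoms, the choice of amine now matters in this assay: isopropylamino gives a step beyond the scatter against dimethylamino (a 4.8-fold lower number from compound 2 to compound 3 (0.68 log units; beyond the scatter)) and against pyrrolidin-1-yl (a 4.0-fold lower number from compound 1 to compound 3 (0.60 log units; beyond the scatter)). The earlier exchange of pyrrolidin-1-yl for dimethylamino (a 1.2-fold higher number from compound 1 to compound 2 (0.08 log units; within the scatter)) had shown no such separation. The change from dimethylamino to isopropylamino alters the hydrogen-bond donor count and the heavy-atom count together, and no data shown here account for the lower number.

Isopropyl(methyl)amino would keep the branched chain without the amine hydrogen, while methylamino, ethylamino and cyclopropylamino would test the amine hydrogen with different chains. Their numbers would show whether the lower number follows the amine hydrogen, the chain, or both.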